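A few compounds are considered here, and "the series" means these few. Any claim that something is new, unique, unknown or untested is made for them only; others in the source may bear on it.

Of the compounds shown here, two sharing one core have so far been measured in a functional assay on MDA-MB-231 cells (Homo sapiens) for antiproliferative activity, read by MTT assay, with a stated time of 72 h; a lower number here means a stronger inhibitor, a higher number a weaker inhibitor. In this test compound 1 (`CC(=O)O[C@H]1CC[C@]2(C)[C@H](CC[C@@](C)(O)[C@H]2CC[C@@H]2C(C)=CC[C@H]3[C@H](CC[C@]3(C)O)C2(C)C)OC1(C)C`) gives 38000 nM, and compound 2 (`CC1=CC[C@H]2[C@@H]1CC=C(C)[C@@H](CC[C@H]1[C@]3(C)CC[C@H](OC(=O)CCC(=O)O)C(C)(C)O[C@H]3CC[C@@]1(C)O)C2(C)C`) gives 29600 nM. These two values lie within the scatter of each other, so compound 2 stands level with compound 1, and both sit in the same high range of concentrations. The next compound, compound 3 (`CC1=CC[C@H]2[C@@H]1CC=C(C)[C@@H](CC[C@H]1[C@]3(C)CC[C@H](OCc4ccccc4)C(C)(C)O[C@H]3CC[C@@]1(C)O)C2(C)C`), keeps that core and differs from compound 2 at a single place: benzyl in place of (2-carboxyethyl)carbonyl on an oxygen on a saturated carbon. The group that enters brings a six-membered aromatic ring and has no hydrogen-bond donors, while the group that leaves has one. Neither measured compound carries a benzyl group, so the data offer no direct guide to this change. In this assay, no step beyond the scatter is expected, with any drift more likely toward a slightly lower number. The expected 1.5-fold lower number from compound 2 to compound 3 (0.17 log units; within the scatter) is therefore small. The estimated value for compound 3 is 20000 nM, with an expected range from 8000 nM to 50000 nM.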

Compound 3, half-maximal inhibitory concentration: 35700 nM
The estimate for compound 3 lay 1.8-fold (0.25 log units) below the measured number, and the stated range covers the measured number.
By their numbers in this assay, from the lowest: compounds 2, 3 and 1 (each within the scatter of the next).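

In this assay, putting benzyl in place of (2-carboxyethyl)carbonyl on an oxygen on a saturated carbon gives a 1.2-fold higher number from compound 2 to compound 3 (0.08 log units; within the scatter), which leaves compound 3 level with compound 2. This pair shows that at this place, a group with one six-membered aromatic ring of carbon only and no hydrogen-bond donors or acceptors reads the same in this test as an open chain with a hydrogen-bond donor and acceptors, even though the two groups have the same number of heavy atoms. No independent measurement bears on why these two groups read alike.

Because the carboxylic acid leaves and the benzene ring enters in the same step, this pair cannot show what either part contributes on its own, or whether the two contributions offset each other. Nor do the compounds shown say whether a free hydroxyl, an amine-bearing chain, a longer chain or a substituted benzyl group on this oxygen would move the number beyond the scatter, so it remains open whether this position can affect the antiproliferative reading at all.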